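A few compounds are considered here, and "the series" means these few. Any claim that something is new, unique, unknown or untested is made for them only; others in the source may bear on it.

Measured compounds:
- compound 1 `CCCCCCC(C)Nc1ccc(NC(=O)c2cc(Cl)ccc2O)c(Cl)c1` — 23500 nM in an ADME assay on A549 cells (Homo sapiens) for cytotoxicity, read by resazurin assay, with a stated time of 48 h; on this read-out lower numbers stand for higher toxicity in this test and higher numbers for lower toxicity in this test
- compound 2 `CCN(CC)c1ccc(NC(=O)c2cc(Cl)ccc2O)c(Cl)c1` — compound 2 gives 55500 nM
- compound 3 `O=C(Nc1ccc(NCc2cccnc2Cl)cc1Cl)c1cc(Cl)ccc1O` — compound 3 gives 101000 nM

Compound 1 gives the lowest number of the three in this assay; its nearest neighbour is compound 2, a 2.4-fold higher number from compound 1 to compound 2 (0.37 log units; beyond the scatter), and the furthest is compound 3, a 4.3-fold higher number from compound 1 to compound 3 (0.63 log units; beyond the scatter). Compounds 2 and 3 lie within the scatter of each other, a 1.8-fold higher number from compound 2 to compound 3 (0.26 log units; within the scatter).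

Compound 4 `O=C(Nc1ccc(NCc2ccc(O)nc2)cc1Cl)c1cc(Cl)ccc1O` is not yet measured. Its change from compound 1 is (6-hydroxypyridin-3-yl)methyl in place of 1-methylheptyl on a nitrogen on an aromatic ring. Among the measured compounds shown here, the step that bears on it most closely is the one from compound 1 to compound 3, where a pyridinylmethyl group also replaced the 1-methylheptyl group on the same nitrogen and gave a 4.3-fold higher number from compound 1 to compound 3 (0.63 log units; beyond the scatter). The step from compound 1 to compound 2, a different replacement on the same position, went the same way, a 2.4-fold higher number from compound 1 to compound 2 (0.37 log units; beyond the scatter). For the measured compounds named here, both replacements of the 1-methylheptyl group raised the number; a step of the same direction and a similar size is therefore expected for compound 4, a 3.4-fold higher number from compound 1 to compound 4 (0.53 log units; beyond the scatter), though no measured compound carries the 6-hydroxypyridin-3-yl group itself. Compound 4 is estimated at 80000 nM, with a range of 30000 nM to 200000 nM.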

Compound 4, half-maximal cytotoxic concentration: 98500 nM
Compound 4: middle estimate off by 1.2-fold (0.09 log units), on the low side; low and high end bracket the measured number.
By their numbers in this assay, from the lowest: compound 1; then compounds 2, 4 and 3 (each within the scatter of the next).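

In this assay, (6-hydroxypyridin-3-yl)methyl in place of 1-methylheptyl on the nitrogen gives a second pyridine-bearing group with a step beyond the scatter (a 4.2-fold higher number from compound 1 to compound 4 (0.62 log units; beyond the scatter)). The two pyridine groups are not told apart: 6-hydroxypyridin-3-yl in place of 2-chloropyridin-3-yl gives a 1.0-fold lower number from compound 3 to compound 4 (0.01 log units; within the scatter), and ((6-hydroxypyridin-3-yl)methyl)amino in place of diethylamino also stays within the scatter (a 1.8-fold higher number from compound 2 to compound 4 (0.25 log units; within the scatter)). Nothing on hand offers an explanation for this result.

As far as these compounds go, whether the low number of compound 1 belongs to the 1-methylheptyl group in particular remains open, and an octyl chain or a cyclohexylmethyl group on the same nitrogen would bear on that. Also open, from the compounds shown here alone, is whether a plain benzyl group, with no ring nitrogen, would fall with compound 3 and compound 4.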